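From 3-methylpiperidin-1-yl to azepan-1-yl on a thiocarbonyl carbon

The compounds below may be only part of what the source reports. "The series", "measured", "known", "first", "only" and "open" are said of these compounds alone.

Of the compounds shown here, three sharing one core have been measured so far. In a toxicity assay on HeLa cells (Homo sapiens) for cytotoxicity, read by MTT assay, with a stated time of 24 h (a lower number here means a stronger inhibitor, a higher number a weaker inhibitor), compound 1 (`Cc1ncc([N+](=O)[O-])n1CC(O)CSC(=S)N1CCOCC1`) gives 4520000 nM while compound 2 (`Cc1ncc([N+](=O)[O-])n1CC(O)CSC(=S)N1CCCCC1`) gives 1400000 nM and compound 3 (`Cc1ncc([N+](=O)[O-])n1CC(O)CSC(=S)N1CCCC(C)C1`) gives 609000 nM as the lowest of the three numbers. Compound 4 (`Cc1ncc([N+](=O)[O-])n1CC(O)CSC(=S)N1CCCCCC1`) has not yet been measured. Its difference from compound 3 is azepan-1-yl in place of 3-methylpiperidin-1-yl on a thiocarbonyl carbon and amounts to azepan-1-yl in place of 3-methylpiperidin-1-yl on a thiocarbonyl carbon, with the same atoms joined differently.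

For the measured compounds named here, no measured step enlarges a ring, so the evidence is indirect. The replacement of morpholin-4-yl by piperidin-1-yl gave a 3.2-fold lower number from compound 1 to compound 2 (0.51 log units; beyond the scatter) and the full change to 3-methylpiperidin-1-yl gave a 7.4-fold lower number from compound 1 to compound 3 (0.87 log units; beyond the scatter) in the same direction. Going by the values given here, the closest precedent is the added methyl, which gave a 2.3-fold lower number from compound 2 to compound 3 (0.36 log units; beyond the scatter) as a modest step. Compound 4 carries no methyl yet keeps the atoms of compound 3, so a position near compound 3 or slightly toward compound 2 seems likely. The expected change is small and upward, given as a 1.3-fold higher number from compound 3 to compound 4 (0.12 log units; within the scatter) in this estimate. In this assay the expected value for compound 4 is 800000 nM with an estimated range from 320000 nM to 2000000 nM on repeated measurement.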

Compound 4, half-maximal inhibitory concentration: 411000 nM
Estimate against measurement, compound 4: 1.9-fold (0.29 log units) above; the measured number falls inside the stated range.
By their numbers in this assay, from the lowest: compounds 4 and 3 (each within the scatter of the next); then compound 2; then compound 1.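

In this assay, rearranging the same atoms from 3-methylpiperidin-1-yl into azepan-1-yl gives a 1.5-fold lower number from compound 3 to compound 4 (0.17 log units; within the scatter), so on this thiocarbonyl carbon a methyl branch is not required to reach the level of compound 3, and an unbranched seven-membered ring serves as well. For the compounds shown here, the first direct comparison of ring size at this place gives a 3.4-fold lower number from compound 2 to compound 4 (0.53 log units; beyond the scatter), showing that enlarging the ring from piperidin-1-yl to azepan-1-yl, with no branch at all, moves the number beyond the scatter, while the full change from morpholin-4-yl gives an 11-fold lower number from compound 1 to compound 4 (1.04 log units; beyond the scatter), the only step in the set printed as large. No independent measurement accompanies these numbers that would explain them, so the compounds show the size of the steps and not what lies behind them.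

The compounds shown leave open whether the numbers keep falling with a still larger ring such as azocan-1-yl, or whether a methyl on the azepan-1-yl ring would add anything to the change already seen. They also leave open how an open-chain amine such as diethylamino, or a piperazin-1-yl ring, would compare at this place.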